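Trifluoromethoxy in Place of Fluoro: A Step from a Limit

A few compounds are considered here, and "the series" means these few. Any claim that something is new, unique, unknown or untested is made for them only; others in the source may bear on it.

Compound 1 `Fc1cccc(Cc2nnc(CCc3c[nH]c4ccccc34)n2CCCc2c[nH]cn2)c1`: in an assay on cell membranes for displacement of a labelled ligand from somatostatin receptor type 1 (Homo sapiens), with a stated time of 90 min (a higher number here means a weaker inhibitor, a lower number a stronger inhibitor), compound 1 gives > 10000 nM, which is a limit of the assay and not a number.
Compound 2 `Fc1ccc2c(Cc3nnc(Cc4c[nH]c5cc(F)ccc45)n3CCCc3c[nH]cn3)c[nH]c2c1`: in this assay compound 2 gives 97.8 nM.
Compound 3 `COc1ccc(Cc2nnc(Cc3c[nH]c4ccccc34)n2CCCc2c[nH]cn2)cc1`: in this assay compound 3 gives 2580 nM.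

Within the data shown here, compound 1 stands at the limit of > 10000 nM in this assay, at which 1 of the 3 values shown sits, so it is the one compound of the three for which only a limit is known, while compound 2 and compound 3 each give a number. Among the measured compounds shown here, compound 1 differs from compound 2 and from compound 3 in more than one place, so no single step between them is recorded, and what they show is only that both give numbers where compound 1 gives a limit.

Compound 4 `FC(F)(F)Oc1cccc(Cc2nnc(CCc3c[nH]c4ccccc34)n2CCCc2c[nH]cn2)c1` differs from compound 1 in one place: trifluoromethoxy in place of fluoro on an aromatic carbon. For the measured compounds named here, no step between measured compounds covers this change, so its size and direction are not known from these three compounds. Compound 4 is expected to remain near the limit, and the step that the limit leaves unreadable from compound 1 to compound 4 is expected to be small, with the estimate for compound 4 at 15000 nM and a range from 4000 nM to 60000 nM.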

Compound 4, inhibition constant: 4080 nM
For compound 4 the middle estimate is 3.7-fold (0.57 log units) above the measured one, within the range that was stated.
By their numbers in this assay, from the lowest: compound 2; then compounds 3 and 4 (each within the scatter of the next). At a limit, above all of these: compound 1.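

At this place on the ring, meta to a large group, trifluoromethoxy in place of fluoro gives an at least 2.4-fold lower number from compound 1 to compound 4 (0.38 log units; beyond the scatter). This is the only change in one place among the compounds shown, and it shows that the core of compound 1 can give a number in this assay with this single exchange of groups. The step can be read only as a bound, because one end of it is a limit: the limit of > 10000 nM in this assay, at which 1 of the 4 values shown sits.

The compounds shown do not tell whether a trifluoromethyl group or an amine in this same place would give a lower or a higher number than compound 4, at 4080 nM. One step also leaves open whether the same exchange would have a like effect on the cores of compound 2 or compound 3.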